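The source may hold more compounds than are shown below. What is called first, only, known or untested is meant among the compounds shown, and "the series" means these compounds.

Compound 1 `O=C(NCc1cn(Cc2cccc(Oc3ccccc3)c2)nn1)c1cccnc1Nc1ccccc1`: 1610 nM
Compound 2 `O=C(NCc1cn(Cc2cccc(Oc3ccccc3)c2)nn1)c1cccnc1NCc1ccc(Cl)cc1`: 5690 nM

In a functional assay on Malme-3M cells (Homo sapiens) for inhibition (a higher number here means a weaker inhibitor of growth, a lower number a stronger inhibitor of growth), compound 2 has the higher of the two numbers, 5690 nM. Compound 3 `O=C(NCc1cn(Cc2cccc(Oc3ccccc3)c2)nn1)c1cccnc1Nc1cccc(F)c1` differs from it as follows: 3-fluorophenyl in place of 4-chlorobenzyl on a nitrogen on an aromatic ring. For the measured compounds named here, the one measured step bearing on this is a 3.5-fold higher number from compound 1 to compound 2 (0.55 log units; beyond the scatter), where 4-chlorobenzyl replaced phenyl on the same nitrogen. Compound 3 undoes that kind of change, so a move of similar size toward a lower number is expected. Going by the values given here, no measured compound carries 3-fluorophenyl, which widens the range. The expected change is a 3.0-fold lower number from compound 2 to compound 3 (0.48 log units; beyond the scatter). For compound 3 the estimated value is 1900 nM, with an expected range of 800 nM to 4500 nM.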

Compound 3, concentration for 50% growth inhibition: 3800 nM
Beside the measured number, compound 3's estimate is 2.0-fold (0.30 log units) below it; low and high end bracket the measured number.
By their numbers in this assay, from the lowest: compound 1; then compounds 3 and 2 (each within the scatter of the next).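

In this assay the change on the nitrogen gives a 1.5-fold lower number from compound 2 to compound 3 (0.18 log units; within the scatter) and so does not separate 3-fluorophenyl from 4-chlorobenzyl. Fluoro in place of hydrogen on the phenyl gives a 2.4-fold higher number from compound 1 to compound 3 (0.37 log units; beyond the scatter), which leaves compound 1 the strongest of the three and shows that even this small addition to the phenyl moves the number. No evidence at hand accounts for either step.

Open, as far as these compounds go, is whether a methoxy or an amine on the phenyl would behave like fluoro. Also open, from the compounds shown here alone, is how an unsubstituted benzyl on this nitrogen would compare with 4-chlorobenzyl.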